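A few compounds are considered here, and "the series" means these few. Any claim that something is new, unique, unknown or untested is made for them only; others in the source may bear on it.

Measured so far:

Compound 1, `CCCNC(=O)[C@@H]1C[C@H]2CCC[C@@H](C1)[C@@H]2NC(=O)c1cc2sc(-c3ccccc3)nc2n1Cc1ccc(OC)cc1` — 0.453 h
Compound 2, `CCCNC(=O)[C@@H]1C[C@H]2CCC[C@@H](C1)[C@@H]2NC(=O)c1cc2sc(Br)nc2n1Cc1ccc(OC)cc1` — 0.867 h
Compound 3, `CCCNC(=O)C1CCN(C(=O)c2cc3sc(-c4ccccc4)nc3n2Cc2ccc(OC)cc2)CC1` — 0.68 h

The three measured compounds were examined in an ADME assay on microsomes from liver (Homo sapiens) for metabolic stability; on this read-out higher numbers stand for a longer-lived compound and lower numbers for a shorter-lived compound. Compound 1 and compound 2 share one core and differ in a single place: bromo in place of phenyl on an aromatic carbon. In this assay this change gave a 1.9-fold higher number from compound 1 to compound 2 (0.28 log units; within the scatter). Compound 3 carries a different core; how the core of compound 3 differs from that of compound 1 is not broken down here. In this assay compound 3 gives 0.68 h, and its value and that of compound 2 lie within the usual scatter of each other, as do its value and that of compound 1.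

Compound 4, `CCCNC(=O)C1CCN(C(=O)c2cc3sc(Br)nc3n2Cc2ccc(OC)cc2)CC1`, has not yet been measured. It stands to compound 3 as compound 2 stands to compound 1: bromo in place of phenyl on an aromatic carbon. The place of the change is described in the same words for both pairs, so this is the same change made on the core of compound 3. Among the compounds with values here, on the assumption that the change behaves on the core of compound 3 as it did on the core of compound 1, the step is expected to be about a 1.8-fold higher number from compound 3 to compound 4 (0.25 log units; within the scatter), placed beside a 1.9-fold higher number from compound 1 to compound 2 (0.28 log units; within the scatter), because a 1.9-fold higher number from compound 1 to compound 2 (0.28 log units; within the scatter) is the only measurement of this change available. Compound 4 is therefore estimated at 1.2 h in this assay, with the likely range expected to run from 0.6 h to 2.4 h.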

Compound 4, half-life: 0.0498 h
Estimate against measurement, compound 4: 24-fold (1.38 log units) above; the measured number lies below the stated range.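

The replacement of phenyl by bromo on an aromatic carbon did not carry over from one core to the other in this assay: the same change on two cores in this assay, a 1.9-fold higher number (0.28 log units; within the scatter) from compound 1 to compound 2 and a 14-fold lower number (1.14 log units; beyond the scatter) from compound 3 to compound 4, 26-fold (1.42 log units) apart, beyond the scatter of two such steps. On the core of compound 3, the change gave a 14-fold lower number from compound 3 to compound 4 (1.14 log units; beyond the scatter), a large step, while the matching step on the core of compound 1 stayed within the scatter; in this series, then, the step measured on one of these cores did not predict the step on the other. These two pairs do not show which part of the two cores sets the steps apart or why they differ, and with a single pair on each core they give no general rule for this change on any further core.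

The compounds shown leave open whether another group on this aromatic carbon, such as chloro, methyl or an amine, would also give different steps on the two cores in this assay. They also leave open whether the contrast between the cores would persist with a longer chain in place of the propyl on the amide, or with a carboxylic acid in place of that amide.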